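The compounds below may be only part of what the source reports. "The series", "measured", "known", "first", "only" and "open" are said of these compounds alone.

Two compounds have been measured in an ADME assay on the whole organism for cytotoxicity, with Artemia salina as the target, with a stated time of 24 h; on this read-out higher numbers stand for an effect only at larger amounts of compound and lower numbers for an effect already at smaller amounts:
compound 1 `Cc1ccc(S(=O)(=O)NC(=O)Nc2ccccc2C(=O)/C=C/c2ccccc2)cc1` gives 25 ug/mL;
compound 2 `Cc1ccc(S(=O)(=O)NC(=O)Nc2ccccc2C(=O)/C=C/c2ccc(F)cc2)cc1` gives 3.96 ug/mL.

Compound 2 stands at the lower of the two numbers. Among the measured compounds shown here, the only measured step, a 6.3-fold lower number from compound 1 to compound 2 (0.80 log units; beyond the scatter), is the sole comparison available. Compound 3 `Cc1ccc(S(=O)(=O)NC(=O)Nc2ccccc2C(=O)/C=C/c2ccccc2Cl)cc1` differs from compound 2 by 2-chlorophenyl in place of 4-fluorophenyl on a double-bonded chain carbon bound to a double-bonded chain carbon. For the measured compounds named here, no measured step exchanges one halogen for another or moves it to a different ring carbon, so the step from compound 1 to compound 2 bears on this change only loosely: it shows that a change on this ring can move the number beyond the scatter, but it does not show in which direction such an exchange would go. Compound 3 is therefore expected to stay near compound 2, with a 1.1-fold higher number from compound 2 to compound 3 (0.06 log units; within the scatter) expected to be small and possibly within the scatter. The estimate for compound 3 in this assay is 4.5 ug/mL, with a range from 1.5 ug/mL to 14 ug/mL.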

Compound 3, concentration for half-maximal effect: 12.8 ug/mL
Compound 3: the middle estimate sits 2.8-fold (0.45 log units) below what was measured, and the stated range covers the measured number.
By their numbers in this assay, from the lowest: compound 2; then compounds 3 and 1 (each within the scatter of the next).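

In this assay the exchange of 4-fluorophenyl for 2-chlorophenyl on a double-bonded chain carbon bound to a double-bonded chain carbon is not neutral: it gives a 3.2-fold higher number from compound 2 to compound 3 (0.51 log units; beyond the scatter), so these two halogen-bearing rings are not interchangeable at this place. Adding the chloro group gives a 2.0-fold lower number from compound 1 to compound 3 (0.29 log units; within the scatter), so this change, unlike fluoro in place of hydrogen in compound 2, does not separate compound 3 from compound 1. No experimental evidence is available to explain the difference between the two halogen-bearing rings.

The compounds shown leave open whether the step between the two rings follows the identity of the halogen or its place on the ring, as both change together. They also leave open how an amine or a carboxylic acid on this ring would compare.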